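Removing the drawn configuration from compound 2

The compounds below may be only part of what the source reports. "The series", "measured", "known", "first", "only" and "open" are said of these compounds alone.

Of the compounds shown here, three that share one core have been measured in a functional assay (brain) for inhibition, with Rattus norvegicus as the target; a lower number here means a stronger inhibitor, a higher number a weaker inhibitor. Compound 2 `Cc1c(C)c2c(c(C)c1O)CC[C@](C)(CC[S+](C)C)O2` gives 2000 nM, the lowest of the three numbers. Compound 1 `Cc1c(C)c2c(c(C)c1O)CCC(C)(CC(=O)[N-][N+](C)(C)C)O2` gives 6000 nM, and compound 3 `Cc1c(C)c2c(c(C)c1O)CC[C@](C)(CC(=O)[N-][N+](C)(C)C)O2` gives 8000 nM. Compound 1 and compound 3 have the same atoms and bonds; a stereocentre at a saturated ring carbon is drawn without a configuration in compound 1 and R in compound 3, and the step from one to the other is a 1.3-fold higher number from compound 1 to compound 3 (0.12 log units; within the scatter). Compound 2 and compound 3 differ in a side group, with the step of a 4.0-fold higher number from compound 2 to compound 3 (0.60 log units; beyond the scatter).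

Compound 4 `Cc1c(C)c2c(c(C)c1O)CCC(C)(CC[S+](C)C)O2` relates to compound 2 as compound 1 relates to compound 3: the two compounds have the same atoms and bonds; at least one stereo element is drawn with a configuration in one of them and without one in the other: 1 of 1 stereo elements differ; a stereocentre at a saturated ring carbon is drawn R in compound 2 and without a configuration in compound 4. Within the data shown here, only the step from compound 1 to compound 3 bears on this change, and it stayed within the scatter. For compound 4 the expected step is therefore a 1.3-fold higher number from compound 2 to compound 4 (0.10 log units; within the scatter), with no change beyond the scatter. In this assay compound 4 is estimated at 2500 nM, within a range from 1200 nM to 5000 nM.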

Compound 4, half-maximal inhibitory concentration: 2000 nM
Compound 4: middle estimate off by 1.3-fold (0.10 log units), on the high side; the range from low to high includes it.
By their numbers in this assay, from the lowest: compounds 2 and 4 (each within the scatter of the next); then compounds 1 and 3 (each within the scatter of the next).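

In this assay, the drawn configuration at the saturated ring carbon makes no readable difference on the side chain holding sulfur: there is no change at the digits printed from compound 2 to compound 4 (within the scatter), which matches what the pair with the longer nitrogen-bearing side chain had suggested. With the ring carbon drawn without a configuration, exchanging the group of 7 heavy atoms for the group of 4 heavy atoms gives a 3.0-fold lower number from compound 1 to compound 4 (0.48 log units; beyond the scatter), so this step no longer rests on a single pair. The side-group change now reads much the same whether or not a configuration is drawn: the same change on two cores in this assay, a 4.0-fold higher number (0.60 log units; beyond the scatter) from compound 2 to compound 3 and a 3.0-fold higher number (0.48 log units; beyond the scatter) from compound 4 to compound 1, 1.3-fold (0.12 log units) apart, within the scatter of two such steps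

The compounds shown leave open how the opposite configuration at the ring carbon would read, as every defined centre here is drawn R. They also leave open where a simple amine, a carboxylic acid or a longer chain carrying the sulfur group would fall at this position.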